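A few compounds are considered here, and "the series" means these few. Any claim that something is new, unique, unknown or untested is made for them only; others in the source may bear on it.

Two compounds have numbers in an assay on RBL-1 cells for inhibition of Polyunsaturated fatty acid 5-lipoxygenase (Rattus norvegicus); on this read-out lower numbers stand for stronger inhibition and higher numbers for weaker inhibition. Compound 1 `CN(O)/C=C\C(=O)c1ccc(Cl)cc1` gives 550 nM in this assay, and compound 2 `O=C(/C=C\N(O)Cc1ccc(-c2ccccc2)cc1)c1ccc(F)cc1` gives 3000 nM in this assay, so compound 2 stands at the higher of the two numbers, a gap that lies beyond the usual scatter. Compound 3 `O=C(/C=C\N(O)Cc1ccc(-c2ccccc2)cc1)c1ccsc1` has not yet been measured; it differs from compound 2 by thiophen-3-yl in place of 4-fluorophenyl on a carbonyl carbon. Going by the values given here, no measured pair shows this change, and the expected step of no change at the digits printed from compound 2 to compound 3 (within the scatter) in this assay is one within the scatter, in no clear direction. Compound 3 is therefore estimated at 3000 nM, with a range from 1000 nM to 9000 nM.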

Compound 3, half-maximal inhibitory concentration: 3000 nM
The estimate for compound 3 equals the measured number at the digits printed; measured number inside the range.
By their numbers in this assay, from the lowest: compound 1; then compounds 2 and 3 (each within the scatter of the next).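

In this assay, going by these compounds alone, the step of no change at the digits printed from compound 2 to compound 3 (within the scatter) gives the first reading at this position on a carbonyl carbon. With the rest of the molecule held constant, the read-out does not separate thiophen-3-yl, a five-membered aromatic ring with one hetero atom, from 4-fluorophenyl, a six-membered aromatic ring of carbon only. Nothing measured here bears on why the two groups read alike.

The compounds shown leave open whether this position would also accept a group without an aromatic ring, such as cyclohexyl or a longer alkyl chain. They also do not show how a basic amine or a carboxylic acid would read there.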